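Removing Two Methyl Groups from Compound 1

The compounds below may be only part of what the source reports. "The series", "measured", "known", "first", "only" and "open" are said of these compounds alone.

In a functional assay on RS4-11 cells (Homo sapiens) for inhibition, read by CCK-8 assay, with a stated time of 48 h (a higher number here means a weaker inhibitor, a lower number a stronger inhibitor), compound 1 `COc1ccc(Oc2ccc(C(C)C)cc2-c2ccsc2S(=O)(=O)NCCNC(=S)Nc2ccc([N+](=O)[O-])cc2)cc1OC` gives 5800 nM and compound 2 `COc1ccc(Oc2ccc(C(C)C)cc2-c2ccsc2S(=O)(=O)NCCNC(=O)Nc2cc(Cl)cc(Cl)c2)cc1OC` gives 9000 nM, so the two stand within the scatter of each other. Compound 3 `CC(C)c1ccc(Oc2ccc(O)c(O)c2)c(-c2ccsc2S(=O)(=O)NCCNC(=S)Nc2ccc([N+](=O)[O-])cc2)c1` has not yet been measured. It differs from compound 1 by 3,4-dihydroxyphenyl in place of 3,4-dimethoxyphenyl on an oxygen on an aromatic ring. Going by the values given here, the only measured step, a 1.6-fold higher number from compound 1 to compound 2 (0.19 log units; within the scatter), lies on an amine nitrogen and not at this place, so it bears on the change only indirectly. Among the compounds with values here, no step at this place has been measured, and the data fix no direction. A small drift toward a lower number is expected, but nothing beyond the scatter, and the expected step is a 1.7-fold lower number from compound 1 to compound 3 (0.22 log units; within the scatter). For compound 3 the estimated value is 3500 nM, with an expected range of 1000 nM to 10000 nM.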

Compound 3, half-maximal inhibitory concentration: 5100 nM
Compound 3: the middle estimate sits 1.5-fold (0.16 log units) below what was measured; the range from low to high includes it.
By their numbers in this assay, from the lowest: compounds 3, 1 and 2 (each within the scatter of the next).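

Going by these compounds alone, this is the first step read at this place, on an oxygen on an aromatic ring, where the earlier compounds offered none. In this assay the exchange of 3,4-dimethoxyphenyl for 3,4-dihydroxyphenyl gives a 1.1-fold lower number from compound 1 to compound 3 (0.06 log units; within the scatter), so the two methyl groups can go and two hydrogen-bond donors can enter with no shift that this read-out can tell from scatter. No measurement at hand offers an explanation for this result.

The compounds shown leave open whether another group at this place, such as a carboxylic acid, an amine or a longer alkoxy chain, would move the number beyond the scatter. They also leave open whether the same exchange would read alike with the group on the amine nitrogen of compound 2.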